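A few compounds are considered here, and "the series" means these few. Any claim that something is new, unique, unknown or untested is made for them only; others in the source may bear on it.

Results so far in a functional assay on COLO 205 cells (Homo sapiens) for inhibition, read by sulforhodamine B assay (a higher number here means a weaker inhibitor of growth, a lower number a stronger inhibitor of growth), are these:

Compound 1 `Oc1cccc2[nH]c(-c3ccc(-c4ccc(-c5ccccc5)cc4)cc3)nc12` gives 1210 nM 
Compound 2 `COc1ccc(-c2ccc(-c3ccc(-c4nc5c(O)cccc5[nH]4)cc3)cc2)cc1` gives 1630 nM 

Compound 2 stands level with compound 1 on these numbers. Within the data shown here, the only measured step between them is a 1.3-fold higher number from compound 1 to compound 2 (0.13 log units; within the scatter), and it comes from putting methoxy in place of hydrogen on an aromatic carbon.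

The next compound is compound 3 `CN(C)c1ccc(-c2ccc(-c3ccc(-c4nc5c(O)cccc5[nH]4)cc3)cc2)cc1`, which has dimethylamino in place of methoxy on an aromatic carbon, para to a large group (dimethylamino in place of methoxy on an aromatic carbon). Cut one bond further out, 4-methoxyphenyl becomes 4-(dimethylamino)phenyl.

Among the measured compounds shown here, no compound carrying dimethylamino has been measured yet, so the guide is thin. For the measured compounds named here, the one step that bears on this change is the swap from compound 1 to compound 2 (a 1.3-fold higher number from compound 1 to compound 2 (0.13 log units; within the scatter)), and it stayed within the scatter. A similarly small result therefore seems most likely, with no step beyond the scatter in this assay and no firm direction.

The expected change is a 1.1-fold lower number from compound 2 to compound 3 (0.04 log units; within the scatter) as an estimate. The expected value for compound 3 is 1500 nM, with an estimated range from 700 nM to 3200 nM as the likely span.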

Compound 3, concentration for 50% growth inhibition: 6320 nM
Compound 3: middle estimate off by 4.2-fold (0.62 log units), on the low side, outside the stated range (above it).
By their numbers in this assay, from the lowest: compounds 1 and 2 (each within the scatter of the next); then compound 3.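

In this assay, this position, para to a large group, does respond to what sits on it: dimethylamino in place of methoxy gives a 3.9-fold higher number from compound 2 to compound 3 (0.59 log units; beyond the scatter), a step beyond the scatter, while the earlier change from hydrogen to methoxy, a 1.3-fold higher number from compound 1 to compound 2 (0.13 log units; within the scatter), stayed within it. Compared directly with hydrogen at the same place, dimethylamino gives a 5.2-fold higher number from compound 1 to compound 3 (0.72 log units; beyond the scatter), so hydrogen and methoxy stand level, and only dimethylamino moves the number, towards weaker growth inhibition. The swap also shows that two groups with the same count of hydrogen-bond donors and acceptors need not behave alike here, and no measurement at hand accounts for the difference between them.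

From the compounds shown here alone, it remains open whether this step belongs to dimethylamino alone or extends to other nitrogen-linked groups at this place, such as a plain amino group or a morpholine ring. Three compounds also cannot show whether a longer chain such as ethoxy, or a carboxylic acid, would stay level with hydrogen and methoxy or move the number as dimethylamino does.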